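Notes on replacing the 4-bromo-2-fluorophenyl of compound 2

The compounds below may be only part of what the source reports. "The series", "measured", "known", "first", "only" and "open" are said of these compounds alone.

Measured in a functional assay on A549 cells (Homo sapiens) for cytotoxicity, read by MTT assay, with a stated time of 72 h; a lower number here means a stronger inhibitor, a higher number a weaker inhibitor:
- compound 1 `Cc1cc(=O)n(-c2ccc(Br)cc2F)nc1C(=O)Nc1ccc(Oc2ncnc3[nH]ccc23)cc1`: 3770 nM
- compound 2 `Cc1cc(=O)n(-c2ccc(Br)cc2F)nc1C(=O)Nc1ccc(Oc2ncnc3c2ccn3C)cc1`: 47300 nM

Compound 2 holds the higher of the two numbers, at 47300 nM. Compound 3 `Cc1cc(=O)n(-c2ccccc2Cl)nc1C(=O)Nc1ccc(Oc2ncnc3c2ccn3C)cc1` differs from it by 2-chlorophenyl in place of 4-bromo-2-fluorophenyl on an aromatic nitrogen. Among the compounds with values here, the one measured step, a 13-fold higher number from compound 1 to compound 2 (1.10 log units; beyond the scatter), is large but concerns methyl in place of hydrogen on an aromatic nitrogen elsewhere in the structure. Within the data shown here, no measured step covers this exchange, so no step beyond the scatter is expected in this assay. The expected change is a 1.4-fold lower number from compound 2 to compound 3 (0.13 log units; within the scatter). For compound 3 the estimate is 35000 nM, with an expected range of 12000 nM to 100000 nM.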

Compound 3, half-maximal inhibitory concentration: 5120 nM
Beside the measured number, compound 3's estimate is 6.8-fold (0.83 log units) above it; the whole stated range lies above it.
By their numbers in this assay, from the lowest: compounds 1 and 3 (each within the scatter of the next); then compound 2.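

In this assay, 2-chlorophenyl in place of 4-bromo-2-fluorophenyl gives a 9.2-fold lower number from compound 2 to compound 3 (0.97 log units; beyond the scatter) and so shows that this group on the aromatic nitrogen can move the number beyond the scatter, which the earlier pair, differing elsewhere in the structure, could not show. Bromine and fluorine leave and chlorine enters in one exchange, so the step cannot be assigned to any single atom. No measured property bears on the origin of this step.

Open, on these data alone, is whether the step persists with hydrogen in place of the methyl, as in compound 1. Also open, as far as these compounds go, is how an amine or a carboxylic acid on this phenyl ring would read.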